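Adding a Second Fluoro: From Compound 3 to Compound 4

The source may hold more compounds than are shown below. What is called first, only, known or untested is meant among the compounds shown, and "the series" means these compounds.

Compound 1 `COc1ccc(-n2nc(Sc3ccc(Cl)cc3)cc(CC[C@@H](C)NC(=O)[C@H]3CNCC[C@@H]3c3ccc(C(F)(F)F)cc3)c2=O)cc1`: in a functional assay with Melanocortin receptor 4 (Homo sapiens) as the target, read by cAMP accumulation (a lower number here means that less compound is needed, a higher number that more compound is needed for the effect), compound 1 gives > 5000 nM, which is a limit of the assay and not a number.
Compound 2 `COc1ccc(-n2nc(Sc3ccc(Cl)cc3)cc(CC[C@@H](C)NC(=O)[C@H]3CNCC[C@@H]3c3ccc(C)cc3)c2=O)cc1`: in this assay compound 2 gives 1100 nM.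
Compound 3 `COc1ccc(-n2nc(Sc3ccc(Cl)cc3)cc(CC[C@@H](C)NC(=O)[C@H]3CNC[C@@H]3c3ccccc3F)c2=O)cc1`: in this assay compound 3 gives 710 nM.

Compound 3 and compound 2 lie within the usual scatter of each other, and compound 1 sits only at a limit, so compound 3 is one of two close measured numbers rather than a clear standout. Compound 4 `COc1ccc(-n2nc(Sc3ccc(Cl)cc3)cc(CC[C@@H](C)NC(=O)[C@H]3CNC[C@@H]3c3ccc(F)cc3F)c2=O)cc1` differs from compound 3 by fluoro in place of hydrogen on an aromatic carbon. For the measured compounds named here, only one step has been measured, an at least 4.5-fold lower number from compound 1 to compound 2 (0.65 log units; beyond the scatter), which swaps one group for another on an aromatic carbon elsewhere in the shared core and so speaks to this change only loosely; the limit of > 5000 nM in this assay, at which 1 of the 3 values shown sits, leaves the full size of that step open. Nothing measured here shows what a single added fluoro does, so no step beyond the scatter is expected, and for compound 4 the expected change is a 1.2-fold lower number from compound 3 to compound 4 (0.07 log units; within the scatter). Compound 4 is therefore estimated at 600 nM in this assay, with a likely range from 250 nM to 1500 nM.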

Compound 4, half-maximal effective concentration: 200 nM
Beside the measured number, compound 4's estimate is 3.0-fold (0.48 log units) above it, and the stated range ends above it.
By their numbers in this assay, from the lowest: compound 4; then compounds 3 and 2 (each within the scatter of the next). At a limit, above all of these: compound 1.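

In this assay, going from 2-fluorophenyl to 2,4-difluorophenyl gives a 3.6-fold lower number from compound 3 to compound 4 (0.55 log units; beyond the scatter) and so lies beyond the scatter. This is the first step shown for a single added fluoro, whereas the only earlier step swapped one group for another elsewhere on the shared core. It shows that this aromatic carbon, para to a large group, is a place where replacing hydrogen with one heavy atom can shift the number needed for the effect, though no measurement shown accounts for the size of the shift.

Going by these compounds, it remains open whether chloro, methoxy or a nitrile at this same place would lower the number as fluoro does. On these data alone, it is also open whether the step depends on the fluoro already on the ring, or would appear on an unsubstituted phenyl too.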